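A few compounds are considered here, and "the series" means these few. Any claim that something is new, unique, unknown or untested is made for them only; others in the source may bear on it.

Compound 1 `CC(C)=CC(=O)Nc1ccn([C@H]2C[C@@H](O)[C@H](O)[C@@H](C)O2)c(=O)n1` gives in a functional assay on HCT-116 cells (Homo sapiens) for cytotoxicity, read by sulforhodamine B assay, with a stated time of 24 h (on this read-out lower numbers stand for stronger inhibition and higher numbers for weaker inhibition), only a limit of > 20000 nM, not a number. Compound 2 `CC(C)C(=O)Nc1ccc(C(=O)Nc2ccn([C@H]3CC[C@H](O[C@H]4O[C@H](C)[C@@H](N(C)C)[C@H](O)[C@H]4O)[C@@H](C)O3)c(=O)n2)cc1` gives 6630 nM in this assay, the only number shown. Compound 1 stands at the limit of > 20000 nM in this assay, at which 1 of the 2 values shown sits. Compound 3 `CCC(C)/C=C/C(=O)Nc1ccn([C@H]2CC[C@H](O[C@H]3O[C@H](C)[C@@H](N(C)C)[C@H](O)[C@H]3O)[C@@H](C)O2)c(=O)n1`, not yet measured, differs from compound 2 as follows: a group of 6 heavy atoms (6 carbon; no ring) in place of a group of 12 heavy atoms (10 carbon, 1 nitrogen, 1 oxygen; one six-membered aromatic ring of carbon only), on a carbonyl carbon. For this change the account expects a step from compound 2 to compound 3 of a 1.8-fold higher number from compound 2 to compound 3 (0.26 log units; within the scatter) in this assay, toward weaker inhibition, beyond the usual scatter. Compound 3 is therefore estimated at 12000 nM, between 3500 nM and 30000 nM.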

Compound 3, half-maximal inhibitory concentration: 890 nM
Compound 3: the middle estimate sits 13-fold (1.13 log units) above what was measured; measured number below the stated range.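

At the carbonyl carbon whose other neighbour is the amide-type nitrogen, replacing the 4-((isopropylcarbonyl)amino)phenyl group with a smaller all-carbon group without a ring gives a 7.4-fold lower number from compound 2 to compound 3 (0.87 log units; beyond the scatter) in this assay. This position therefore accepts a group with no aromatic ring and no hydrogen-bond donor or acceptor, and the number still falls. Nothing measured here bears on the cause of this step.

The compounds shown leave open whether losing the ring or gaining the chain drives the step. On these data alone, how a longer chain, an amine or a carboxylic acid would read at this carbonyl carbon also remains open.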